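The compounds below may be only part of what the source reports. "The series", "measured", "known", "first", "only" and "open" are said of these compounds alone.

Compound 1 `Cc1ccc2c(=O)c(CSC(=S)N3CCCCC3)coc2c1` is the starting point of this account. For the measured compounds named here, in a functional assay on MCF7 cells (Homo sapiens) for antiproliferative activity, read by MTT assay, with a stated time of 72 h (a lower number here means a stronger inhibitor, a higher number a weaker inhibitor), compound 1 gives 800 nM, and it is the only compound here with a numerical reading. Compound 2 `O=c1cc(CSC(=S)N2CCCCC2)oc2cc(Cl)ccc12` shares the core but is reported in this assay only as a limit: compound 2 gives > 25000 nM. That reading sits at the limit of > 25000 nM in this assay, at which 1 of the 2 values shown sits, so it is a limit and not a number. Compound 3 `Cc1ccc2c(=O)c(CSC(=S)N3CCOCC3)coc2c1` has not yet been measured in this assay. It differs from compound 1 by morpholin-4-yl in place of piperidin-1-yl on a thiocarbonyl carbon. No measured pair among these compounds shows the effect of such a swap, so no step size for it is recorded. Resting on compound 1 alone, the step from compound 1 to compound 3 in this assay is expected to be small, a modest weakening at the most and possibly none beyond the scatter. The expected step is a 1.9-fold higher number from compound 1 to compound 3 (0.27 log units; within the scatter). For compound 3 the estimated value in this assay is 1500 nM, with a range from 500 nM to 5000 nM.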

Compound 3, half-maximal inhibitory concentration: 20700 nM
The estimate for compound 3 lay 14-fold (1.14 log units) below the measured number; measured number above the stated range.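

For the compounds shown here, the thiocarbonyl carbon, for which no measured pair existed before, now has one: in this assay, morpholin-4-yl in place of piperidin-1-yl gives a 26-fold higher number from compound 1 to compound 3 (1.41 log units; beyond the scatter). The two groups are both six-membered non-aromatic rings of 6 heavy atoms, and they differ in that morpholin-4-yl holds an oxygen and 1 hydrogen-bond acceptor, so a swap that leaves the ring size unchanged is still enough to separate compound 3 clearly from compound 1. Nothing shown here gives a measured reason for this large step.

The compounds shown leave open whether other amines on the same thiocarbonyl carbon, such as pyrrolidin-1-yl, dimethylamino or 4-methylpiperazin-1-yl, would read close to compound 1 or close to compound 3, and so whether the oxygen itself or some other feature of the ring sets the reading. They also leave open whether the same swap carries the same step on a core with a group other than methyl, such as chloro, since this single pair speaks only for the core of compound 1.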